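The compounds below may be only part of what the source reports. "The series", "measured", "known", "first", "only" and "open" are said of these compounds alone.

Three compounds share one core and differ only in the group attached to an amide-type nitrogen within a carbamate side chain. Compound 1 `COc1nc(C)c(Nc2nc(Cl)cn([C@H](COC(=O)Nc3ccccc3)C3CC3)c2=O)cc1C` carries a plain phenyl there, and in an assay on frontal cortex for displacement of a labelled ligand from corticotropin-releasing factor receptor 1 (Rattus norvegicus), with a stated time of 2 h (a higher number here means a weaker inhibitor, a lower number a stronger inhibitor), compound 1 gives 1.5 nM. Compound 2 `COc1nc(C)c(Nc2nc(Cl)cn([C@H](COC(=O)Nc3ccc(Cl)cc3Cl)C3CC3)c2=O)cc1C` carries a 2,4-dichlorophenyl instead, and in this assay compound 2 gives 1.7 nM. Compound 3 `COc1nc(C)c(Nc2nc(Cl)cn([C@H](COC(=O)Nc3cc(Cl)cc(Cl)c3)C3CC3)c2=O)cc1C` carries a 3,5-dichlorophenyl, and in this assay compound 3 gives 1.7 nM. The three numbers sit close together: a 1.1-fold higher number from compound 1 to compound 2 (0.05 log units; within the scatter), a 1.1-fold higher number from compound 1 to compound 3 (0.05 log units; within the scatter), and no change at the digits printed from compound 2 to compound 3 (within the scatter). Compound 3 thus stands level with compound 2 and within the scatter of compound 1; none of the three can be called stronger than another.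

Compound 4 `COc1ccc(NC(=O)OC[C@H](C2CC2)n2cc(Cl)nc(Nc3cc(C)c(OC)nc3C)c2=O)c(C)n1` is not yet measured. Its change from compound 3 is 6-methoxy-2-methylpyridin-3-yl in place of 3,5-dichlorophenyl on an amide-type nitrogen. The measured steps all concern this same position, and each stayed within the scatter, which suggests the group on this nitrogen has had little influence so far. None of them, however, exchanged a carbon-only ring for a ring with a hetero atom and hydrogen-bond acceptors, so the precedent is only partial. The expected step is therefore small, a 1.5-fold higher number from compound 3 to compound 4 (0.17 log units; within the scatter), leaning toward a slightly higher number only to allow for the untested nature of the change. The estimate for compound 4 in this assay is 2.5 nM, with a range from 0.8 nM to 8 nM.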

Compound 4, half-maximal inhibitory concentration: 9.2 nM
The estimate for compound 4 lay 3.7-fold (0.57 log units) below the measured number; measured number above the stated range.
By their numbers in this assay, from the lowest: compounds 1, 2 and 3 (each within the scatter of the next); then compound 4.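

The group on this amide-type nitrogen does matter in this assay: replacing 3,5-dichlorophenyl with 6-methoxy-2-methylpyridin-3-yl gives a 5.4-fold higher number from compound 3 to compound 4 (0.73 log units; beyond the scatter), which makes compound 4 the weakest inhibitor of the four. The same replacement gives a 5.4-fold higher number from compound 2 to compound 4 (0.73 log units; beyond the scatter) when set against the 2,4-dichlorophenyl group and a 6.1-fold higher number from compound 1 to compound 4 (0.79 log units; beyond the scatter) when set against plain phenyl, so the loss, modest in size, appears whichever of the three earlier groups is the starting point, even though swapping among those groups moved the number only within the scatter. No measurement here explains why the number rises.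

The new group brings a ring nitrogen, a methoxy and a methyl in a single change, and removes both chlorines, so the compounds shown cannot say which of these features accounts for the step. A plain pyridin-3-yl, a methoxyphenyl or a methylphenyl on this nitrogen would begin to separate them, while a cyclohexyl or a short alkyl chain would test whether an aromatic ring is needed here at all.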